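Oxadiazolyl for Cyano on a Metabolically Stable Core

This account rests on a few compounds, and the source may have more. Where it says the series, first, only, none or still open, it means among the compounds named here.

Compound 1 `CC(C)[C@H]1C(O)=C(C2=NS(=O)(=O)c3c(OCC#N)cccc32)C(=O)N1Cc1ccccc1` was examined in an in vitro ADME assay on microsomes from liver (Homo sapiens) for metabolic stability; on this read-out higher numbers stand for a longer-lived compound and lower numbers for a shorter-lived compound. In this assay compound 1 gives > 1 h, which is a limit of the assay and not a number. Compound 2 `CC(C)[C@H]1C(O)=C(C2=NS(=O)(=O)c3c(OCc4ncon4)cccc32)C(=O)N1Cc1ccccc1` carries 1,2,4-oxadiazol-3-yl in place of cyano on a saturated chain carbon bound to an oxygen on an aromatic ring. In this assay compound 2 likewise gives > 1 h, again a limit rather than a number. The step that the two limits leave unreadable from compound 1 to compound 2 therefore stays unreadable, the two limits hiding its size. Compound 3 `CC(C)(C)[C@H]1C(O)=C(C2=NS(=O)(=O)c3c(OCC#N)cccc32)C(=O)N1Cc1ccc(F)c(Cl)c1` rests on a core that differs from the core of compound 1; the difference between the two cores is not broken down here. In this assay compound 3 gives > 1 h, also a limit. All three values share this position, as the limit of > 1 h in this assay, at which 3 of the 3 values shown sit, records.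

Compound 4 `CC(C)(C)[C@H]1C(O)=C(C2=NS(=O)(=O)c3c(OCc4ncon4)cccc32)C(=O)N1Cc1ccc(F)c(Cl)c1` is compound 3 with 1,2,4-oxadiazol-3-yl in place of cyano on a saturated chain carbon bound to an oxygen on an aromatic ring, the same change that turns compound 1 into compound 2. Because a step that the two limits leave unreadable from compound 1 to compound 2 could not be read and because the limit of > 1 h in this assay, at which 3 of the 3 values shown sit, places every value at the limit, the expected step that the limit leaves unreadable from compound 3 to compound 4 is small. For compound 4 the estimated half-life is 1.5 h, with an expected range from 0.7 h to 4 h, and most likely the assay again reports only its limit.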

Compound 4, half-life: > 1 h
Compound 4: only a limit was reported; the forecaster's own chance of this, stated with the estimate: 80%; the middle value is on the limit's open side.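

In this assay compound 4 gives > 1 h, a limit of the assay and not a number. No step from compound 3 to compound 4 can be read, and all values shown share one position: the limit of > 1 h in this assay, at which 4 of the 4 values shown sit.

The compounds shown leave open how long each one actually lasts, and whether 1,2,4-oxadiazol-3-yl in place of cyano changes the half-life on either core.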